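This account rests on a few compounds, and the source may have more. Where it says the series, first, only, none or still open, it means among the compounds named here.

Measured so far:
compound 1, `Oc1cccc(-c2cc(-c3cccc(F)c3)cc(-c3cccc(O)c3)n2)c1`: in a functional assay on HeLa cells (Homo sapiens) for inhibition (a higher number here means a weaker inhibitor, a lower number a stronger inhibitor), compound 1 gives 1400 nM
compound 2, `Oc1ccc(-c2cc(-c3cccc(F)c3)cc(-c3cccc(O)c3)n2)cc1`: in this assay compound 2 gives 14200 nM

Going by the values given here, compound 2 stands at the highest of the two numbers in this assay; its only neighbour is compound 1, and the step of a 10-fold higher number from compound 1 to compound 2 (1.01 log units; beyond the scatter) separates the two. That step concerns the hydroxyphenyl group on the shared core and nothing else.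

Compound 3, `Oc1ccc(-c2cc(-c3ccc(C(F)(F)F)cc3)cc(-c3cccc(O)c3)n2)cc1`, is not yet measured. Its change from compound 2 is 4-(trifluoromethyl)phenyl in place of 3-fluorophenyl on an aromatic carbon. Among the compounds with values here, no measured step touches this group: the single step on record alters a different substituent, so nothing measured bears on the fluorophenyl exchange. Without a precedent, the working expectation is no step beyond the scatter in this assay, in either direction, and the range is set wide. The expected step of a 1.0-fold lower number from compound 2 to compound 3 (0.01 log units; within the scatter) reflects that. Compound 3 is estimated at 14000 nM, within 4000 nM to 50000 nM.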

Compound 3, half-maximal inhibitory concentration: 17300 nM
Compound 3: middle estimate off by 1.2-fold (0.09 log units), on the low side; measured number inside the range.
By their numbers in this assay, from the lowest: compound 1; then compounds 2 and 3 (each within the scatter of the next).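

In this assay, the position opposite the ring nitrogen takes 4-(trifluoromethyl)phenyl in place of 3-fluorophenyl with a 1.2-fold higher number from compound 2 to compound 3 (0.09 log units; within the scatter), so this exchange of group, ring placement of the fluorinated substituent included, leaves no step beyond the scatter. Going by these compounds alone, the only earlier step concerned the hydroxyphenyl group, so this is the first reading at this position, and in this pair the position is far less sensitive to the change made than the hydroxyphenyl group was to its own. No separate measurement bears on this result.

On these data alone, this position has been read only with a 4-hydroxyphenyl group on the core, so the same exchange alongside the two 3-hydroxyphenyl groups of compound 1 remains open. Also open, as far as these compounds go, is whether an amine or a carboxylic acid on this phenyl ring would give a step beyond the scatter.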